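This account rests on a few compounds, and the source may have more. Where it says the series, first, only, none or still open, it means among the compounds named here.

Compound 1 `COc1ccc(-c2cc(C(=O)/C=C/c3ccccc3)nc3cc(-c4ccccc4)nn23)cc1OC` gives 23300 nM in a functional assay on MDA-MB-231 cells (Homo sapiens) for antiproliferative activity, read by MTT assay, with a stated time of 24 h; a higher number here means a weaker inhibitor, a lower number a stronger inhibitor.
Compound 2 `COc1cc(-c2cc(C(=O)/C=C/c3ccccc3)nc3cc(-c4ccccc4)nn23)cc(OC)c1OC` gives 19200 nM in this assay.
Compound 3 `COc1cc(-c2cc(/C=C/C(=O)c3ccccc3)nc3cc(-c4ccccc4)nn23)cc(OC)c1OC` gives 15800 nM in this assay.

Compound 2 sits second highest among these three numbers, its values and those of compound 1 and compound 3 all lying within the scatter of one another. Compound 4 `COc1cc(/C=C/C(=O)c2cc(-c3cc(OC)c(OC)c(OC)c3)n3nc(-c4ccccc4)cc3n2)cc(OC)c1OC` differs from compound 2 by 3,4,5-trimethoxyphenyl in place of phenyl on a double-bonded chain carbon bound to a double-bonded chain carbon. Among the compounds with values here, the only step that bears on adding methoxy groups to an aromatic ring is a 1.2-fold lower number from compound 1 to compound 2 (0.08 log units; within the scatter), which stayed within the scatter, although that change sat on the other aryl ring. The step of a 1.2-fold lower number from compound 2 to compound 3 (0.08 log units; within the scatter) concerns the orientation of the chain and is less relevant. Compound 4 is therefore expected to show a step of a 1.3-fold lower number from compound 2 to compound 4 (0.11 log units; within the scatter), not beyond the scatter. Compound 4 is estimated at 15000 nM, in a range of 6000 nM to 40000 nM.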

Compound 4, half-maximal inhibitory concentration: 18400 nM
Beside the measured number, compound 4's estimate is 1.2-fold (0.09 log units) below it; the measured number falls inside the stated range.
By their numbers in this assay, from the lowest: compounds 3, 4, 2 and 1 (each within the scatter of the next).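

Placing 3,4,5-trimethoxyphenyl in place of phenyl on a double-bonded chain carbon bound to a double-bonded chain carbon gives a 1.0-fold lower number from compound 2 to compound 4 (0.02 log units; within the scatter) in this assay and so leaves the number within the scatter. The earlier compounds shown here had tested added methoxy groups only on the other aryl ring, and this result shows that the same kind of change at this position also produces no step that can be told from the scatter. Nothing available explains this result.

The compounds shown leave open whether an amine or a carboxylic acid on this ring would move the number beyond the scatter. They also leave open whether any group here would do so.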